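Notes on the step from compound 3 to compound 4

The source may report more compounds than this note shows. Statements on the series, on what has been measured and on what is new or still open speak of the compounds shown alone.

compound 1 `COc1ccc(/C=C/C(=O)c2ccc(N)c(-c3ccc(F)cc3)c2)cc1O` is recorded as "not determined" (no result reported)
compound 2 `COc1ccc(/C=C/C(=O)c2cccc(-c3ccc(F)cc3)c2)cc1` gives 8350 nM
compound 3 `COc1cc(/C=C/C(=O)c2ccc(N)c(-c3ccc(F)cc3)c2)ccc1O` gives 8350 nM

In a functional assay on SW480 cells (Homo sapiens) for cytotoxicity, read by sulforhodamine B assay, with a stated time of 48 h (a higher number here means a weaker inhibitor, a lower number a stronger inhibitor), compound 3 stands at 8350 nM, level with compound 2 at 8350 nM. Compound 1 offers no number for comparison. The next compound to be measured is compound 4 `COc1ccc(/C=C/C(=O)c2ccc(N)c(-c3ccc(F)cc3)c2)cc1`, which has 4-methoxyphenyl in place of 4-hydroxy-3-methoxyphenyl on a double-bonded chain carbon bound to a double-bonded chain carbon.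

For the measured compounds named here, no measured pair isolates this change, so its size in this assay is not known from a direct comparison. The nearest guide is compound 2, which carries the same 4-methoxyphenyl and gives 8350 nM. On that basis, no change beyond the scatter is expected, and no direction is favoured. The estimated size is a 1.0-fold lower number from compound 3 to compound 4 (0.02 log units; within the scatter). For compound 4 the expected value is 8000 nM, with an estimated range of 3000 nM to 20000 nM.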

Compound 4, half-maximal inhibitory concentration: 7230 nM
Compound 4: middle estimate off by 1.1-fold (0.04 log units), on the high side; measured number inside the range.
By their numbers in this assay, from the lowest: compounds 4, 2 and 3 (each within the scatter of the next).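

In this assay the swap of 4-hydroxy-3-methoxyphenyl for 4-methoxyphenyl on a double-bonded chain carbon bound to a double-bonded chain carbon now has a direct reading, a 1.2-fold lower number from compound 3 to compound 4 (0.06 log units; within the scatter) and so within the scatter, which means this pair does not separate the two groups. For the compounds shown here, the first reading for amino in place of hydrogen on an aromatic carbon is a 1.2-fold lower number from compound 2 to compound 4 (0.06 log units; within the scatter) and also lies within the scatter, so neither single change in these pairs moves the number measurably. Nothing available here speaks to the reason for either result.

Still open, as far as these compounds go, is whether a carboxylic acid or an acetamide in place of amino on that aromatic carbon would move the number. The same holds for a 3,4-dimethoxyphenyl or a 4-fluorophenyl group on the double-bonded chain carbon.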